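The source may hold more compounds than are shown below. What is called first, only, known or untested is meant among the compounds shown, and "the series" means these compounds.

Of the compounds shown here, three have been measured in a functional assay on LoVo/DX cells (Homo sapiens) for antiproliferative activity, read by sulforhodamine B assay, with a stated time of 72 h; on this read-out lower numbers stand for stronger inhibition and higher numbers for weaker inhibition. Compound 1 (`CC(=O)N[C@@H](CSC(=S)NCCCOCCOCCOCCCNC(=S)SC[C@H](NC(C)=O)C(=O)O)C(=O)O`) gives 7930 nM, compound 2 (`CC(=O)N[C@@H](CSC(=S)Nc1ccc(C)c(NC(=S)SC[C@H](NC(C)=O)C(=O)O)c1)C(=O)O`) gives 22400 nM and compound 3 (`CCCNC(=S)SC[C@H](NC(C)=O)C(=O)O`) gives 112000 nM. Compound 3 therefore stands as the weakest of the three, with the highest number, and its gap to each of the others lies beyond the scatter. Compound 4 (`CCCCCNC(=S)SC[C@H](NC(C)=O)C(=O)O`) has not yet been measured. It departs from compound 3 in one place: ethyl in place of hydrogen on a saturated chain carbon, three bonds along the chain from an amide-type nitrogen. This puts ethyl in place of hydrogen on a saturated chain carbon, three bonds along the chain from an amide-type nitrogen, so that propyl becomes pentyl.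

Within the data shown here, no two measured compounds differ in only one place, so the data offer no direct guide to the effect of this change. In this assay a modest step towards a lower number is expected, one that may not clear the scatter. This expectation rests only on the position of compound 3 at 112000 nM, which leaves more room for a fall than for a rise. The expected step is a 1.7-fold lower number from compound 3 to compound 4 (0.24 log units; within the scatter). For compound 4 the estimated value is 65000 nM, with an expected range from 28000 nM to 130000 nM.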

Compound 4, half-maximal inhibitory concentration: 42800 nM
Compound 4: middle estimate off by 1.5-fold (0.18 log units), on the high side, within the range that was stated.
By their numbers in this assay, from the lowest: compound 1; then compounds 2 and 4 (each within the scatter of the next); then compound 3.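

In this assay, among these compounds, the position now has its first direct reading, a 2.6-fold lower number from compound 3 to compound 4 (0.42 log units; beyond the scatter), a modest step that clears the scatter, whereas the earlier compounds included no pair differing in one place. It shows that ethyl in place of hydrogen on a saturated chain carbon, three bonds along the chain from an amide-type nitrogen, lowers the number, so that on this one pair pentyl is favoured over propyl. Nothing given here accounts for the size or direction of this step, so it stands as an observation without an assigned cause.

A single pair cannot show whether the number keeps falling as the chain grows, and the compounds shown leave open how butyl or a longer chain such as heptyl would read. Going by these compounds, they also leave open whether the same position would tolerate a group other than a plain saturated chain, such as a terminal amine, a terminal carboxylic acid or a phenyl ring, so the reach of this step beyond propyl and pentyl remains unknown.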